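A few compounds are considered here, and "the series" means these few. Any claim that something is new, unique, unknown or untested is made for them only; others in the source may bear on it.

Measured in a functional assay on HepG2 cells (Homo sapiens) for cytotoxicity, read by sulforhodamine B assay, with a stated time of 24 h; on this read-out lower numbers stand for stronger inhibition and higher numbers for weaker inhibition:
- Compound 1 `N#CCC(=O)N/N=C1\C(=O)Nc2ccc(S(=O)(=O)N3CCOCC3)cc21`: 7530 nM
- Compound 2 `N/N=C1\C(=O)Nc2ccc(S(=O)(=O)N3CCOCC3)cc21`: 32400 nM
- Compound 3 `O=C1Nc2ccc(S(=O)(=O)N3CCOCC3)cc2/C1=N/c1ccc(/N=C2\C(=O)Nc3ccc(S(=O)(=O)N4CCOCC4)cc32)cc1`: 8840 nM

Of these three, compound 2 gives the highest number, 32400 nM. Compound 4 `O=C1Nc2ccc(S(=O)(=O)N3CCOCC3)cc2/C1=N/NS(=O)(=O)c1ccccc1` has phenylsulfonyl in place of hydrogen on an amine nitrogen. Going by the values given here, the one measured step at this nitrogen is a 4.3-fold higher number from compound 1 to compound 2 (0.63 log units; beyond the scatter), which is modest but beyond the scatter and removes (cyanomethyl)carbonyl. Among the compounds with values here, no measured compound shows phenylsulfonyl itself, so this is thin support. Read in reverse, it points to a modest fall in this assay when the hydrogen is replaced. The estimated step is a 3.2-fold lower number from compound 2 to compound 4 (0.51 log units; beyond the scatter), of similar size and towards a lower number. For compound 4 the expected value is 10000 nM, with an estimated range of 4000 nM to 25000 nM.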

Compound 4, half-maximal inhibitory concentration: 23900 nM
Beside the measured number, compound 4's estimate is 2.4-fold (0.38 log units) below it; the measured number falls inside the stated range.
By their numbers in this assay, from the lowest: compounds 1 and 3 (each within the scatter of the next); then compounds 4 and 2 (each within the scatter of the next).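

In this assay, phenylsulfonyl on this amine nitrogen gives a 1.4-fold lower number from compound 2 to compound 4 (0.13 log units; within the scatter), so this large group does not separate from plain hydrogen here. Acyl and sulfonyl groups are therefore not interchangeable at this nitrogen: replacing (cyanomethyl)carbonyl with phenylsulfonyl gives a 3.2-fold higher number from compound 1 to compound 4 (0.50 log units; beyond the scatter) and loses the modest gain seen with compound 1. Nothing available explains this difference between the two groups. Whether the nitrile or the carbonyl of compound 1 accounts for its lower number remains open. So does the place of a simple acetyl group or a longer alkyl chain on this nitrogen.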